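Series notes: phenoxy replaced by (3,5-dichloropyridin-2-yl)oxy

The compounds below may be only part of what the source reports. "The series", "measured", "known", "first", "only" and "open" are said of these compounds alone.

Three compounds of the shared core carry different groups on the same aromatic carbon. Compound 1 `O=C(O)c1ccc2noc(-c3ccc(-c4cccnc4)cc3)c2c1` gives 610 nM in an assay for inhibition of inositol hexakisphosphate kinase 3 (Homo sapiens), read by colorimetric assay, coupled enzyme assay and malachite green, with a stated time of 120 min, in the presence of a further agent that is not named here; on this read-out higher numbers stand for weaker inhibition and lower numbers for stronger inhibition. Compound 2 `O=C(O)c1ccc2noc(-c3ccc(N4CCCCC4)cc3)c2c1` gives 1790 nM in this assay, and compound 3 `O=C(O)c1ccc2noc(-c3ccc(Oc4ccccc4)cc3)c2c1` gives 550 nM in this assay. Compound 3 holds the lowest of the three numbers; its nearest neighbour is compound 1, the two lying within the scatter of each other, as a 1.1-fold lower number from compound 1 to compound 3 (0.04 log units; within the scatter) shows, while the furthest is compound 2, with a 3.3-fold lower number from compound 2 to compound 3 (0.51 log units; beyond the scatter). The remaining pair is separated by a 2.9-fold higher number from compound 1 to compound 2 (0.47 log units; beyond the scatter).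

Compound 4 `O=C(O)c1ccc2noc(-c3ccc(Oc4ncc(Cl)cc4Cl)cc3)c2c1` differs from compound 3 by 3,5-dichloropyridin-2-yl in place of phenyl on an oxygen on an aromatic ring. Among the compounds with values here, none of the measured steps alters the ring held on the oxygen; all three exchange the whole group on the aromatic carbon. Within the data shown here, the steps that bear on the question are those into compound 3, a 1.1-fold lower number from compound 1 to compound 3 (0.04 log units; within the scatter) and a 3.3-fold lower number from compound 2 to compound 3 (0.51 log units; beyond the scatter), which place the phenoxy group level with pyridin-3-yl and below piperidin-1-yl, but say nothing about substitution within the phenoxy ring itself. The step of a 1.1-fold lower number from compound 3 to compound 4 (0.04 log units; within the scatter) is therefore expected to stay within the scatter, with the direction unresolved. Compound 4 is expected to give 500 nM in this assay, with a range from 150 nM to 1600 nM.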

Compound 4, half-maximal inhibitory concentration: 2250 nM
For compound 4 the middle estimate is 4.5-fold (0.65 log units) below the measured one; measured number outside the range, above it.
By their numbers in this assay, from the lowest: compounds 3 and 1 (each within the scatter of the next); then compounds 2 and 4 (each within the scatter of the next).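

Within the ring held on the oxygen, substitution is not neutral in this assay: 3,5-dichloropyridin-2-yl in place of phenyl gives a 4.1-fold higher number from compound 3 to compound 4 (0.61 log units; beyond the scatter), so this outer ring is a site of change in its own right, which the earlier exchanges of the whole group on the aromatic carbon could not show. The oxygen link alone does not keep a group level with pyridin-3-yl, since (3,5-dichloropyridin-2-yl)oxy gives a 3.7-fold higher number from compound 1 to compound 4 (0.57 log units; beyond the scatter), beyond the scatter, whereas phenoxy lies within the scatter of pyridin-3-yl; against piperidin-1-yl, the same group gives a 1.3-fold higher number from compound 2 to compound 4 (0.10 log units; within the scatter), within the scatter. No supporting evidence is available to explain this step.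

The step brings in the ring nitrogen and both chlorines together, so the compounds shown do not separate their contributions; the plain pyridin-2-yl ether and the 3,5-dichlorophenyl ether would divide the step between them. Also open, as far as these compounds go, is whether a single chlorine or a methoxy on the phenoxy ring would leave the number level with compound 3 or move it as far as compound 4.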